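Chloro in Place of Hydrogen on Compound 3

The compounds below may be only part of what the source reports. "The series", "measured", "known", "first", "only" and "open" are said of these compounds alone.

Measured in a functional assay on L1210 cells (Mus musculus) for antiproliferative activity, with a stated time of 48 h; a lower number here means a stronger inhibitor, a higher number a weaker inhibitor:
- compound 1 (`C=C(Br)C(=O)Nc1ccc(/C=C/C(=O)c2ccccc2)cc1`): 5000 nM
- compound 2 (`C=C(Br)C(=O)Nc1ccc(C(=O)/C=C/c2cccc(OC)c2)cc1`): 1100 nM
- compound 3 (`Nc1ccc(/C=C/C(=O)c2ccccc2)cc1`): 88000 nM

Of these three, compound 3 gives the highest number, 88000 nM, which makes it the weakest inhibitor of the set. The next structure, compound 4 (`Nc1ccc(/C=C/C(=O)c2ccc(Cl)cc2)cc1`), carries chloro in place of hydrogen on an aromatic carbon.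

Within the data shown here, only one single-place step has been measured, an 18-fold higher number from compound 1 to compound 3 (1.25 log units; beyond the scatter). That large step comes from a change on the nitrogen, with hydrogen in place of (1-bromoethenyl)carbonyl, so it says nothing directly about chloro on an aromatic carbon. Compound 2 differs from the others in more than one place and offers no clean comparison. Among the measured compounds shown here, with no measured step for this change, only a modest shift can be expected in this assay, perhaps towards a lower number, since compound 3 already stands highest at 88000 nM. The estimated change is a 1.8-fold lower number from compound 3 to compound 4 (0.25 log units; within the scatter). For compound 4 the expected value is 50000 nM, with an estimated range from 15000 nM to 130000 nM.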

Compound 4, half-maximal inhibitory concentration: 111000 nM
Compound 4: the middle estimate sits 2.2-fold (0.35 log units) below what was measured; measured number inside the range.
By their numbers in this assay, from the lowest: compound 2; then compound 1; then compounds 3 and 4 (each within the scatter of the next).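

In this assay, chloro in place of hydrogen on an aromatic carbon, para to a large group, gives a 1.3-fold higher number from compound 3 to compound 4 (0.10 log units; within the scatter), so this change leaves the number unmoved as far as the measurement can tell. Among these compounds, the only earlier single-place step, an 18-fold higher number from compound 1 to compound 3 (1.25 log units; beyond the scatter), lay on the nitrogen, and the new step adds that a chloro at this aromatic position does not bring a compound with a free amine on its nitrogen into the range of the compounds carrying (1-bromoethenyl)carbonyl. The data available offer no explanation for this flat result.

As far as these compounds go, whether chloro would also make so little difference with (1-bromoethenyl)carbonyl on the nitrogen remains open. From the compounds shown here alone, it is equally open whether a different group on this same carbon, such as a nitrile or a carboxylic acid, would shift the number.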